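The compounds below may be only part of what the source reports. "The series", "measured", "known", "first", "only" and "open" are said of these compounds alone.

The compounds here share one core and differ only in what sits on an aromatic nitrogen. In a functional assay on MDA-MB-231 cells (Homo sapiens) for antiproliferative activity (a higher number here means a weaker inhibitor, a lower number a stronger inhibitor), compound 1 `O=C(CCCCCCC(=O)Nc1ccc(Nc2nc(-c3cn[nH]c3)c3cc[nH]c3n2)cc1)NO` gives 11800 nM, compound 2 `CCCn1cc(-c2nc(Nc3ccc(NC(=O)CCCCCCC(=O)NO)cc3)nc3[nH]ccc23)cn1` gives 9100 nM, and compound 3 `C=CCCn1cc(-c2nc(Nc3ccc(NC(=O)CCCCCCC(=O)NO)cc3)nc3[nH]ccc23)cn1` gives 7400 nM. These three numbers lie within the scatter of one another, so compound 3 stands level with the other two, not clear of them.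

The next structure, compound 4 `CS(=O)(=O)CCn1cc(-c2nc(Nc3ccc(NC(=O)CCCCCCC(=O)NO)cc3)nc3[nH]ccc23)cn1`, carries methylsulfonyl in place of vinyl on a saturated chain carbon, two bonds along the chain from an aromatic nitrogen.

Going by the values given here, three measured steps bear on this change. Putting propyl on the aromatic nitrogen gives a 1.3-fold lower number from compound 1 to compound 2 (0.11 log units; within the scatter), and putting but-3-en-1-yl there gives a 1.6-fold lower number from compound 1 to compound 3 (0.20 log units; within the scatter). Closest to the new change, vinyl in place of methyl at the same place gives a 1.2-fold lower number from compound 2 to compound 3 (0.09 log units; within the scatter). All three stay within the scatter, so among these compounds the chain has not yet moved the number measurably. Going by these compounds, none of them carries methylsulfonyl, however, so the new group is untested and the range must stay wide.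

The expected size is a 1.1-fold higher number from compound 3 to compound 4 (0.03 log units; within the scatter), which means no expected move beyond the scatter in either direction. For compound 4 the estimated value is 8000 nM, with an expected range from 3500 nM to 18000 nM.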

Compound 4, half-maximal inhibitory concentration: > 100000 nM
Compound 4: only a limit was reported; the forecaster's own chance of this, stated with the estimate: 5%; at least 12-fold (1.09 log units) between middle value and limit.
By their numbers in this assay, from the lowest: compounds 3, 2 and 1 (each within the scatter of the next). At a limit, above all of these: compound 4.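

In this assay, the reading for compound 4 is a limit of the assay and not a number: the limit of > 100000 nM in this assay, at which 1 of the 4 values shown sits. Methylsulfonyl in place of vinyl gives an at least 13-fold higher number from compound 3 to compound 4 (1.13 log units; beyond the scatter), methylsulfonyl in place of methyl gives an at least 10-fold higher number from compound 2 to compound 4 (1.04 log units; beyond the scatter), and 2-(methylsulfonyl)ethyl in place of hydrogen on the aromatic nitrogen gives an at least 8.4-fold higher number from compound 1 to compound 4 (0.92 log units; beyond the scatter). The position is therefore not indifferent to what it carries: propyl and but-3-en-1-yl left the number within the scatter of compound 1, whereas the chain ending in methylsulfonyl makes compound 4 a clearly weaker inhibitor than compounds 1, 2 and 3.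

Compound 4 is the only compound here with a methylsulfonyl group, so the compounds shown cannot tell whether the sulfur-oxygen group itself or some other feature of this chain accounts for the drop, and the limit leaves its full size unknown. A chain ending in a methyl ether, an amine or a carboxylic acid, or a longer chain carrying methylsulfonyl further from the aromatic nitrogen, would show how narrow this tolerance is.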